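The source may report more compounds than this note shows. Statements on the series, on what has been measured and on what is new or still open speak of the compounds shown alone.

Measured so far:
compound 1 `O=C(c1ccc(F)cc1)N1CC(c2nc(-c3cccc(Cl)c3)no2)C1`: > 10000 nM
compound 2 `O=C(C1CCC(C(F)(F)F)CC1)N1CC(c2nc(-c3cccc(F)c3)no2)C1`: 680 nM

In an assay on HEK293 cells for positive allosteric modulation of metabotropic glutamate receptor 5 (Homo sapiens), read by FLIPR (on this read-out higher numbers stand for an effect only at larger amounts of compound and lower numbers for an effect already at smaller amounts), compound 1 gives > 10000 nM, which is a limit of the assay and not a number, so compound 1 stands at the limit of > 10000 nM in this assay, at which 1 of the 2 values shown sits. In this assay compound 2 gives 680 nM. Compound 3 `COC1CCCN(C(=O)N2CC(c3nc(-c4cccc(Cl)c4)no3)C2)C1` is not yet measured; it differs from compound 1 by 3-methoxypiperidin-1-yl in place of 4-fluorophenyl on a carbonyl carbon. Going by the values given here, no measured pair shows this change, so its size cannot be read off. The step of an at least 3.3-fold lower number from compound 1 to compound 3 (0.52 log units; beyond the scatter) is expected to run downward, beyond the scatter. That expectation rests on compound 2, whose non-aromatic group on the carbonyl comes with 680 nM. Compound 3 is estimated at 3000 nM, ranging from 500 nM to 15000 nM.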

Compound 3, half-maximal effective concentration: > 10000 nM
Compound 3 gave a limit, no number (the forecaster's own chance of this, stated with the estimate: 40%); middle value at least 3.3-fold (0.52 log units) away from the limit.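

Compound 1 and compound 3 both end at a limit of the assay, so no step can be read between them: the limit of > 10000 nM in this assay, at which 2 of the 3 values shown sit.

From the compounds shown here alone, whether 3-methoxypiperidin-1-yl in place of 4-fluorophenyl on a carbonyl carbon changes the read-out at all remains open.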